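Benzyl Ester to Acid on a Purine Glycine Amide Series

A few compounds are considered here, and "the series" means these few. Any claim that something is new, unique, unknown or untested is made for them only; others in the source may bear on it.

Three compounds built on a shared core were tested in a functional assay on the whole organism (Tail, strain ICR) with Mus musculus as the target, in the tail flick test, with a stated time of 120 min, at a dose of 25 umol/kg by the oral route; a lower number here means a weaker effect, a higher number a stronger effect of the compound at the dose given. Compound 1, `O=C(CN(c1nc(Cl)nc2[nH]cnc12)C1CC1)NCC(=O)OCc1ccccc1`, gave 21.7%. Compound 2, `O=C(O)CNC(=O)CN(c1nc(Cl)nc2[nH]cnc12)C1CC1`, gave 19.8%. Compound 3, `CC(C)C[C@H](NC(=O)CN(c1nc(Cl)nc2[nH]cnc12)C1CC1)C(=O)OCc1ccccc1`, gave 8.58%, the lowest of the three, and the step of a number 13.1 percentage points lower from compound 1 to compound 3 (beyond the scatter) is described as modest and beyond the scatter; the difference between the cores of compound 1 and compound 3 is isobutyl in place of hydrogen on a saturated chain carbon bound to an amide-type nitrogen and a carbonyl carbon.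

The change from compound 1 to compound 2 is hydrogen in place of benzyl on an oxygen next to a carbonyl group, and the step it made, a number 1.9 percentage points lower from compound 1 to compound 2 (within the scatter), lies within the scatter, so the two values are not distinguished. Compound 4, `CC(C)C[C@H](NC(=O)CN(c1nc(Cl)nc2[nH]cnc12)C1CC1)C(=O)O`, has not yet been measured in this assay. Within the data shown here, it differs from compound 3 by hydrogen in place of benzyl on an oxygen next to a carbonyl group, the same change, at the same place, as the one from compound 1 to compound 2.

Because a number 1.9 percentage points lower from compound 1 to compound 2 (within the scatter) was within the scatter, the step from compound 3 to compound 4 is expected to be small as well, estimated as a number 1.1 percentage points lower from compound 3 to compound 4 (within the scatter). This expectation rests on a single measured pair, so the uncertainty is wide. Compound 4 is therefore estimated to show 7.5% in this assay, with a likely range from 0% to 18%.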

Compound 4, a percentage reported as activity, at one dose (the size of the read-out at that dose, not a potency): 18.7%
Compound 4: the middle estimate sits 11.2 percentage points below what was measured, outside the stated range (above it).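

In this assay, hydrogen in place of benzyl on an oxygen next to a carbonyl group gave a number 10.1 percentage points higher from compound 3 to compound 4 (beyond the scatter), and on the acids, isobutyl in place of hydrogen gave a number 1.1 percentage points lower from compound 2 to compound 4 (within the scatter). Among these compounds, the benzyl change cannot be said to behave differently on the two cores, even though only one of its two steps lies beyond the scatter: the same change on two cores in this assay, a number 1.9 percentage points lower (within the scatter) from compound 1 to compound 2 and a number 10.1 percentage points higher (beyond the scatter) from compound 3 to compound 4, 12 percentage points apart, within the scatter of two such steps. Among the compounds shown here, this does not show that the change has one fixed size wherever it is made, since only two pairs are available and their steps stand far apart in size, and the isobutyl change must be read with the same caution: the same change on two cores in this assay, a number 13.1 percentage points lower (beyond the scatter) from compound 1 to compound 3 and a number 1.1 percentage points lower (within the scatter) from compound 2 to compound 4, 12 percentage points apart, within the scatter of two such steps.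

The compounds shown leave open how the benzyl change would read with a group other than hydrogen or isobutyl on the saturated chain carbon, such as methyl or a longer branched chain. They also leave open whether a methyl ester in place of the benzyl ester, or a primary amide in place of the carboxylic acid, would fall in the same range in this assay.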